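The compounds below may be only part of what the source reports. "The series", "measured", "known", "first", "only" and "open" are said of these compounds alone.

Compound 1 `Cc1cccc(C)c1NC(=O)/C=C/C(=O)N1C/C(=C\c2ccccc2)C(=O)/C(=C/c2ccccc2)C1` stands at the higher end of the two measured numbers: in a functional assay on Molt4/C8 cells (Homo sapiens) for cytotoxicity (a lower number here means a stronger inhibitor, a higher number a weaker inhibitor), compound 1 gives 6600 nM, whereas compound 2 `O=C(/C=C/C(=O)N1C/C(=C\c2ccc([N+](=O)[O-])cc2)C(=O)/C(=C/c2ccc([N+](=O)[O-])cc2)C1)Nc1ccc(Cl)c(Cl)c1` gives 600 nM, a gap beyond the scatter. Compound 3 `Cc1ccc(NC(=O)/C=C/C(=O)N2C/C(=C\c3ccccc3)C(=O)/C(=C/c3ccccc3)C2)cc1C` keeps the shared core of compound 1 and differs from it only by 3,4-dimethylphenyl in place of 2,6-dimethylphenyl on an amide-type nitrogen. Within the data shown here, no measured pair isolates this change, so little can be inferred about its size. A small step is expected, and the expected step is a 1.3-fold lower number from compound 1 to compound 3 (0.12 log units; within the scatter), most likely within the scatter. Compound 3 is therefore estimated at 5000 nM, with a range from 2000 nM to 12000 nM.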

Compound 3, half-maximal inhibitory concentration: 7900 nM
Compound 3: middle estimate off by 1.6-fold (0.20 log units), on the low side; measured number inside the range.
By their numbers in this assay, from the lowest: compound 2; then compounds 1 and 3 (each within the scatter of the next).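

Among these compounds, this is the first pair that isolates a change on the amide-type nitrogen: 3,4-dimethylphenyl in place of 2,6-dimethylphenyl gives a 1.2-fold higher number from compound 1 to compound 3 (0.08 log units; within the scatter) in this assay. With the same atoms joined differently, the placement of the two methyl groups on this ring leaves the read-out within the scatter for this pair. Nothing available accounts for this result.

As far as these compounds go, whether another group on this nitrogen, such as a pyridine ring or a morpholine, would move the number remains open. Compound 2 differs from compound 1 and compound 3 in more than one place, so its value cannot be assigned to any single change.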